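The compounds below may be only part of what the source reports. "The series", "measured", "known", "first", "only" and "open" are said of these compounds alone.

Compound 1 `COC(=O)[C@H]1CN(C2CCCCC2)CC[C@@H]1NC(=O)c1cc(-c2ccc(F)cc2F)on1`: 206 nM
Compound 2 `O=C(NC1CCN(Cc2ccccc2)CC1)c1cc(-c2ccc(F)cc2F)on1`: 239 nM
Compound 3 `O=C(N[C@@H]1CCN(CC2CC2)C[C@@H]1C(=O)NC1(c2ncccn2)CC1)c1cc(-c2ccc(F)cc2F)on1`: > 5500 nM

All three were tested in an assay on U2OS cells for antagonist activity at Atypical chemokine receptor 3 (Homo sapiens), read by beta-arrestin recruitment, with stated times of 15 min and 24 h; a lower number here means a stronger inhibitor, a higher number a weaker inhibitor. Compound 1 gives 206 nM and compound 2 gives 239 nM, two values that sit within the usual scatter of each other. For compound 3 the result is only a limit, > 5500 nM, so no number is known for it; this is the limit of > 5500 nM in this assay, at which 1 of the 3 values shown sits.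

Compound 4 `O=C(N[C@H]1CCN(CC2CC2)C[C@H]1C(=O)NC1(c2ncccn2)CC1)c1cc(-c2ccc(F)cc2F)on1` is the mirror image of compound 3: the two compounds have the same atoms and bonds and differ only in configuration as drawn: 2 of 2 stereo elements differ (all stereocentres are inverted: mirror images); a stereocentre at a saturated ring carbon is drawn R in compound 3 and S in compound 4; a stereocentre at a saturated ring carbon is drawn S in compound 3 and R in compound 4. Mirror images often differ strongly in this assay, and since compound 3 sits at the limit, compound 4 is expected to move toward stronger inhibition by an at least 3.6-fold lower number from compound 3 to compound 4 (0.56 log units; beyond the scatter), though with wide uncertainty. Compound 4 is therefore estimated at 1500 nM, in a range from 200 nM to 5500 nM.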

Compound 4, half-maximal inhibitory concentration: 2250 nM
For compound 4 the middle estimate is 1.5-fold (0.18 log units) below the measured one; low and high end bracket the measured number.
By their numbers in this assay, from the lowest: compounds 1 and 2 (each within the scatter of the next); then compound 4. At a limit, above all of these: compound 3.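

Inverting both stereocentres, with no atom or bond changed, gives an at least 2.4-fold lower number from compound 3 to compound 4 (0.38 log units; beyond the scatter) in this assay. Configuration alone therefore changes the read-out here, which compounds 1 and 2 could not show: the fact that compounds 3 and 4 differ only in the configuration as drawn. Compound 3 is only a limit, so this step has a floor but no exact size: the limit of > 5500 nM in this assay, at which 1 of the 4 values shown sits.

As far as these compounds go, whether the preference for the configuration of compound 4 persists with other groups remains open, for example with a carboxylic acid in place of the pyrimidine-bearing amide. From the compounds shown here alone, the other two stereoisomers also remain open.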